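The source may report more compounds than this note shows. Statements on the series, on what has been measured and on what is new or still open speak of the compounds shown alone.

Compounds measured so far:
compound 1 `CC(C)=CC[C@@H](OC(=O)c1ccoc1)C1=CC(=O)c2c(O)ccc(O)c2C1=O`: > 100000 nM
compound 2 `CC(C)=CC[C@@H](OC[C@@H](C)O)C1=CC(=O)c2c(O)ccc(O)c2C1=O`: 22500 nM

In a functional assay on HeLa cells (Homo sapiens) for cytotoxicity, read by MTT assay (on this read-out higher numbers stand for weaker inhibition and lower numbers for stronger inhibition), compound 1 gives only a limit, > 100000 nM, and stands at the limit of > 100000 nM in this assay, at which 1 of the 2 values shown sits. Compound 2 gives 22500 nM; the step of an at least 4.4-fold lower number from compound 1 to compound 2 (0.64 log units; beyond the scatter) is the only one measured. Compound 3 `CC(C)=CC[C@@H](OC(=O)C1CCCCO1)C1=CC(=O)c2c(O)ccc(O)c2C1=O` differs from compound 1 by oxan-2-yl in place of furan-3-yl on a carbonyl carbon. Among the measured compounds shown here, the one measured step removes the whole ester, while here the ester stays and only its ring changes, so no step bears directly on this change. Compound 3 is therefore expected to stay near the limit, a step of a number no higher from compound 1 to compound 3 (the limit leaves the size open), with an estimated 100000 nM (range 35000 nM to 300000 nM).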

Compound 3, half-maximal inhibitory concentration: > 100000 nM
Compound 3 ended at the assay's limit (the forecaster's own chance of this, stated with the estimate: 60%); the middle value lies on the limit itself.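

In this assay compound 3 gives > 100000 nM, which is a limit and not a number. The step between the furan-3-yl and oxan-2-yl esters therefore cannot be read, but an aromatic and a non-aromatic ring on the carbonyl both leave the ester at the limit: the limit of > 100000 nM in this assay, at which 2 of the 3 values shown sit. Replacing 2-hydroxypropyl with (oxan-2-yl)carbonyl gives an at least 4.4-fold higher number from compound 2 to compound 3 (0.64 log units; beyond the scatter), so both esters shown lie on the weaker side of that group.

On these data alone, whether any ester at this position can give a readable value stays open. An amine on the ring or a longer chain on the carbonyl might answer that.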